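The source may hold more compounds than are shown below. What is called first, only, known or untested is meant among the compounds shown, and "the series" means these compounds.

Measured so far:
Compound 1, `O=C(Nc1cc(C(F)(F)F)cc(C(F)(F)F)c1)c1cnc(Cl)nc1`: 300 nM
Compound 2, `Cc1nc(C(F)(F)F)ncc1C(=O)Nc1cc(C(F)(F)F)cc(C(F)(F)F)c1`: > 10000 nM
Compound 3, `O=C(Nc1cc(C(F)(F)F)cc(C(F)(F)F)c1)c1cnc(C(F)(F)F)nc1C(F)(F)F`: > 10000 nM

In an assay on Jurkat cells for activation of nuclear factor NF-kappa-B complex (Homo sapiens) (on this read-out higher numbers stand for weaker inhibition and lower numbers for stronger inhibition), compound 1 gives 300 nM. For compound 2 the value > 10000 nM is a limit of this assay, not a number. For compound 3 the value > 10000 nM is likewise a limit. Compound 3 thus stands at the limit of > 10000 nM in this assay, at which 2 of the 3 values shown sit, and nothing finer can be said of where it lies. For the measured compounds named here, the one measured step, a step that the two limits leave unreadable from compound 2 to compound 3, runs between two limits and gives no readable size.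

The unmeasured compound 4, `O=C(Nc1cc(C(F)(F)F)cc(C(F)(F)F)c1)c1cnc(C(F)(F)F)nc1`, differs from compound 3 by hydrogen in place of trifluoromethyl on an aromatic carbon. Going by the values given here, no measured step bears on this change directly. What the numbers show is that compound 1, which carries hydrogen at that place, gives a number in this assay, whereas compound 3 sits at a limit. On that basis compound 4 is expected to return to a measurable number, and the step from compound 3 to compound 4 is estimated as an at least 12-fold lower number from compound 3 to compound 4 (1.09 log units; beyond the scatter). Compound 4 is therefore expected at about 800 nM, in the range 150 nM to 5000 nM.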

Compound 4, half-maximal inhibitory concentration: > 10000 nM
Compound 4: no number, only a limit (the forecaster's own chance of this, stated with the estimate: 20%); middle value at least 12-fold (1.09 log units) from the limit.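

In this assay, hydrogen in place of trifluoromethyl on this aromatic carbon, next to the ring nitrogen, does not by itself lift compound 3 off the limit, so the hydrogen shared with compound 1 is not enough to give a number. The change that now stands out is at the other ring carbon, where chloro gives way to trifluoromethyl: this gives an at least 33-fold higher number from compound 1 to compound 4 (1.52 log units; beyond the scatter). The steps from compound 2 and from compound 3 to compound 4 cannot be read, since each runs between two limits: the limit of > 10000 nM in this assay, at which 3 of the 4 values shown sit.

The compounds shown leave open whether any group other than chloro at that carbon, such as an amine, a methoxy group or a nitrile, gives a number. They also leave open whether methyl or trifluoromethyl next to the ring nitrogen would still allow a number with chloro kept in place.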